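Replacing cyano with methoxycarbonyl: what to expect

The compounds below may be only part of what the source reports. "The series", "measured", "known", "first", "only" and "open" are said of these compounds alone.

Compound 1 `COc1ccc(S(=O)(=O)N2CCc3cccc(Nc4ccc(O)cc4)c32)cc1`: 239 nM
Compound 2 `COc1ccc(S(=O)(=O)N2CCc3cccc(Nc4ccccc4)c32)cc1`: 342 nM
Compound 3 `COc1ccc(S(=O)(=O)N2CCc3cccc(Nc4ccc(C#N)cc4)c32)cc1`: 49.7 nM

These three compounds share one core and were tested in a functional assay on KB cells (Homo sapiens) for antiproliferative activity; on this read-out lower numbers stand for stronger inhibition and higher numbers for weaker inhibition. Compound 3 has the lowest number of the three, and it stands clear of both others. Compound 4 `COC(=O)c1ccc(Nc2cccc3c2N(S(=O)(=O)c2ccc(OC)cc2)CC3)cc1` has not yet been measured. It carries methoxycarbonyl in place of cyano on an aromatic carbon, para to a large group: methoxycarbonyl in place of cyano on an aromatic carbon.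

Among the measured compounds shown here, two measured steps bear on this change, since both introduce the cyano group that now leaves. The first is a 6.9-fold lower number from compound 2 to compound 3 (0.84 log units; beyond the scatter) and the second is a 4.8-fold lower number from compound 1 to compound 3 (0.68 log units; beyond the scatter). Both are modest but real. By contrast, a 1.4-fold higher number from compound 1 to compound 2 (0.16 log units; within the scatter) shows no separable difference between hydroxy and hydrogen. For the measured compounds named here, no measured compound carries methoxycarbonyl, so the data cannot show whether it matches cyano. Compound 3 reached 49.7 nM with cyano in this place, so part of that gain is expected to be lost, giving a modest rise in this assay that is smaller than those two steps. The expected change is a 2.4-fold higher number from compound 3 to compound 4 (0.38 log units; beyond the scatter). The estimate for compound 4 is 120 nM. The expected range for compound 4 runs from 40 nM to 350 nM.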

Compound 4, half-maximal inhibitory concentration: 93.5 nM
The estimate for compound 4 lay 1.3-fold (0.11 log units) above the measured number, and the stated range covers the measured number.
By their numbers in this assay, from the lowest: compounds 3 and 4 (each within the scatter of the next); then compounds 1 and 2 (each within the scatter of the next).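

In this assay, this change at this position gives no separable difference: a 1.9-fold higher number from compound 3 to compound 4 (0.27 log units; within the scatter), so methoxycarbonyl and cyano cannot be told apart here. The advantage seen with cyano is therefore not confined to that one group, since methoxycarbonyl also stands clear of both earlier comparators, with a 3.7-fold lower number from compound 2 to compound 4 (0.56 log units; beyond the scatter) against hydrogen and a 2.6-fold lower number from compound 1 to compound 4 (0.41 log units; beyond the scatter) against hydroxy. The place on the aromatic carbon, para to a large group, also accepts a substituent of 4 heavy atoms in place of one of 2 without a loss that can be separated from the scatter, so among these four compounds the two groups form one tier and hydrogen and hydroxy the other.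

Nothing available explains why methoxycarbonyl and cyano fall together here, or what sets them apart from hydrogen and hydroxy. The compounds shown leave open whether a carboxylic acid, a primary amide or a longer ester such as ethoxycarbonyl would stay with these two groups or fall back towards hydrogen and hydroxy.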